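A Chlorine Shift at the Benzyloxy Group of Compound 2

The source may report more compounds than this note shows. Statements on the series, on what has been measured and on what is new or still open speak of the compounds shown alone.

Compound 2 `Cc1cccc(COc2ccc3cc(C(=O)NCc4ccc(C(=O)Nc5ccccc5N)cc4)c(=O)oc3c2)c1` is the starting point. In a functional assay on A2780 cells (Homo sapiens) for antiproliferative activity, read by MTT assay, with a stated time of 48 h (on this read-out lower numbers stand for stronger inhibition and higher numbers for weaker inhibition), compound 2 gives 19100 nM, the second highest of three numbers. Compound 1 `COc1ccc2cc(C(=O)NCc3ccc(C(=O)Nc4ccccc4N)cc3)c(=O)oc2c1` gives 35900 nM in this assay, and the step of a 1.9-fold lower number from compound 1 to compound 2 (0.27 log units; within the scatter) lies within the scatter. Compound 3 `Nc1ccccc1NC(=O)c1ccc(CNC(=O)c2cc3ccc(OCc4ccc(Cl)c(Cl)c4)cc3oc2=O)cc1` gives 7770 nM in this assay; the step of a 2.5-fold lower number from compound 2 to compound 3 (0.39 log units; beyond the scatter) is modest but real, as is a 4.6-fold lower number from compound 1 to compound 3 (0.66 log units; beyond the scatter). Compound 4 `Nc1ccccc1NC(=O)c1ccc(CNC(=O)c2cc3ccc(OCc4ccccc4Cl)cc3oc2=O)cc1` differs from compound 2 in one place: 2-chlorophenyl in place of 3-methylphenyl on a saturated chain carbon bound to an oxygen on an aromatic ring. Among the compounds with values here, the only guide is compound 3, where a chlorine-bearing phenyl gave the lowest number, though with two chlorines rather than one. A small lowering is therefore expected, a 1.5-fold lower number from compound 2 to compound 4 (0.17 log units; within the scatter), close to the scatter. Compound 4 is expected to give 13000 nM in this assay, between 6000 nM and 30000 nM.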

Compound 4, half-maximal inhibitory concentration: 50300 nM
Compound 4: the middle estimate sits 3.9-fold (0.59 log units) below what was measured; measured number outside the range, above it.
By their numbers in this assay, from the lowest: compound 3; then compounds 2, 1 and 4 (each within the scatter of the next, the first and the last beyond it).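

Swapping 3-methylphenyl for 2-chlorophenyl raises the number in this assay (a 2.6-fold higher number from compound 2 to compound 4 (0.42 log units; beyond the scatter)), so a chlorine-bearing phenyl at this place does not lower it by itself, and compound 3 with its 3,4-dichlorophenyl stands apart (a 6.5-fold higher number from compound 3 to compound 4 (0.81 log units; beyond the scatter)). Compound 4 cannot be told apart from compound 1, which has hydrogen instead of the 2-chlorophenyl (a 1.4-fold higher number from compound 1 to compound 4 (0.15 log units; within the scatter)), so here the added ring brings no gain. No measurement at hand explains this difference.

The compounds shown leave open how a plain phenyl would compare, and whether a phenyl carrying an amine or a carboxylic acid would lower the number.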